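The source may hold more compounds than are shown below. What is called first, only, known or untested is meant among the compounds shown, and "the series" means these compounds.

- compound 1 `COc1ccc2[nH]c(-c3cn(-c4ccccc4)nc3-c3ccccc3)nc2c1`: 1230 nM
- compound 2 `COc1ccc2[nH]c(-c3cn(-c4ccccc4)nc3-c3ccc(F)cc3)nc2c1`: 1960 nM
- compound 3 `Clc1ccc(-c2nn(-c3ccccc3)cc2-c2nc3cc(Cl)ccc3[nH]2)cc1`: 1340 nM

These values come from a functional assay on A549 cells (Homo sapiens) for antiproliferative activity, read by MTT assay, with a stated time of 48 h; a lower number here means a stronger inhibitor, a higher number a weaker inhibitor. Compound 3 stands among the other two, and all three values lie within the usual scatter of one another. The move to compound 4 `COc1ccc2[nH]c(-c3cn(-c4ccccc4)nc3-c3ccc(Cl)cc3)nc2c1` is methoxy in place of chloro on an aromatic carbon. Among the measured compounds shown here, no measured step makes this exact swap. For the measured compounds named here, the only step available, a 1.6-fold higher number from compound 1 to compound 2 (0.20 log units; within the scatter), is a different change and lies within the scatter. Compound 1, with methoxy, gives 1230 nM, and compound 3, with chloro, gives 1340 nM, so no shift beyond the scatter is expected. The expected change is a 1.1-fold higher number from compound 3 to compound 4 (0.05 log units; within the scatter). For compound 4 the estimate is 1500 nM, with an expected range from 800 nM to 2800 nM.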

Compound 4, half-maximal inhibitory concentration: 2420 nM
Compound 4: the middle estimate sits 1.6-fold (0.21 log units) below what was measured, within the range that was stated.
By their numbers in this assay, from the lowest: compounds 1, 3, 2 and 4 (each within the scatter of the next).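

Methoxy in place of chloro at this position gives a 1.8-fold higher number from compound 3 to compound 4 (0.26 log units; within the scatter), so this swap on the fused ring system stays small. Chloro in place of hydrogen gives a 2.0-fold higher number from compound 1 to compound 4 (0.29 log units; within the scatter), and chloro in place of fluoro gives a 1.2-fold higher number from compound 2 to compound 4 (0.09 log units; within the scatter), so these two changes also stay inside the scatter. No supporting data are available to explain any of these steps. On these data alone, whether an amine or a carboxylic acid at this position would move the number beyond the scatter remains open.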